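This account rests on a few compounds, and the source may have more. Where it says the series, first, only, none or still open, it means among the compounds named here.

Three compounds share one core and differ only in the group on the oxygen on a saturated carbon. Compound 1 `C[C@H]1CC[C@@H]2C(C)(C)[C@H](OS(C)(=O)=O)CC[C@@]2(C)[C@@H]1/C=C/c1ccc(-c2cccc(F)c2)cn1` carries a methylsulfonyl group there, and in a functional assay on HEK293 cells for antagonist activity at proteinase-activated receptor 1 (Homo sapiens), read by FLIPR and calcium flux, with a stated time of 15 min (a lower number here means a stronger inhibitor, a higher number a weaker inhibitor), compound 1 gives 87000 nM. Compound 2 `CC(=O)O[C@@H]1CC[C@@]2(C)[C@H](/C=C/c3ccc(-c4cccc(F)c4)cn3)[C@@H](C)CC[C@@H]2C1(C)C` carries an acetyl group in its place. In this assay compound 2 reaches only the limit of the assay, > 100000 nM. Compound 3 `CCCC(=O)O[C@@H]1CC[C@@]2(C)[C@H](/C=C/c3ccc(-c4cccc(F)c4)cn3)[C@@H](C)CC[C@@H]2C1(C)C` carries a propylcarbonyl group. In this assay compound 3 likewise sits at the limit, > 100000 nM, which is the limit of > 100000 nM in this assay, at which 2 of the 3 values shown sit. The steps of an at least 1.1-fold higher number from compound 1 to compound 2 (0.06 log units; that floor lies within the scatter) and an at least 1.1-fold higher number from compound 1 to compound 3 (0.06 log units; that floor lies within the scatter) are therefore only floors, and the step that the two limits leave unreadable from compound 2 to compound 3 cannot be read at all. Compound 3 thus stands at the edge of what the assay reports, with no readable distance from compound 1 or compound 2.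

Compound 4 `CCOC(=O)O[C@@H]1CC[C@@]2(C)[C@H](/C=C/c3ccc(-c4cccc(F)c4)cn3)[C@@H](C)CC[C@@H]2C1(C)C` differs from compound 3 by ethoxy in place of propyl on a carbonyl carbon. Within the data shown here, no measured step covers this exchange directly. Among the measured compounds shown here, the steps of an at least 1.1-fold higher number from compound 1 to compound 2 (0.06 log units; that floor lies within the scatter) and an at least 1.1-fold higher number from compound 1 to compound 3 (0.06 log units; that floor lies within the scatter) show only that either acyl group carries the value to the limit, and the step that the two limits leave unreadable from compound 2 to compound 3 between the two acyl groups is unreadable. Compound 4 is therefore expected to stay at or near the limit, with the step of a number no higher from compound 3 to compound 4 (the limit leaves the size open) expected to be nothing beyond the scatter. For compound 4 the estimate in this assay is 100000 nM, in a range from 40000 nM to 300000 nM.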

Compound 4, half-maximal inhibitory concentration: > 100000 nM
Compound 4 was reported as a limit; the forecaster's own chance of this, stated with the estimate: 70%; the middle value sits exactly at the limit.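

In this assay, among these compounds, compound 4 also reaches only a limit, so exchanging propyl for ethoxy on a carbonyl carbon brings no readable value, and a third group with a carbonyl carbon on this oxygen ends at the same edge of the read-out: the limit of > 100000 nM in this assay, at which 3 of the 4 values shown sit. The one step that can be read at all is only a floor, an at least 1.1-fold higher number from compound 1 to compound 4 (0.06 log units; that floor lies within the scatter), so it shows no separation from compound 1 beyond the scatter, and the steps among compound 2, compound 3 and compound 4 cannot be read. Among the compounds shown here, compound 1, the only one of the four with a methylsulfonyl group, is also the only one with a measured number, 87000 nM, though the data do not show that this group and the three carbonyl-bearing groups truly differ.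

On these data alone, how far compound 2, compound 3 and compound 4 lie beyond the limit stays open, and so does any ordering among them. Also open, as far as these compounds go, is whether a free hydroxyl, an amine or a carboxylic acid at this position would give a value clearly inside the range of this assay.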